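Amide nitrogen substituent: from 3-fluorophenyl toward isobutyl

This account rests on a few compounds, and the source may have more. Where it says the series, first, only, none or still open, it means among the compounds named here.

Measured so far:
compound 1 `COc1cc2nccc(Oc3ccc(Nc4nn(C)cc4C(=O)Nc4ccccc4F)cc3)c2cc1C(N)=O` — 1710 nM
compound 3 `COc1cc2nccc(Oc3ccc(Nc4nn(C)cc4C(=O)Nc4cccc(F)c4)cc3)c2cc1C(N)=O` — 4480 nM
compound 2 `COc1cc2nccc(Oc3ccc(Nc4nn(C)cc4C(=O)NCC4CCCCC4)cc3)c2cc1C(N)=O` — a limit, > 10000 nM

In a functional assay on BaF3 cells (Mus musculus) for antiproliferative activity, read by CCK-8 assay and cell counting, with a stated time of 76 h (on this read-out higher numbers stand for weaker inhibition and lower numbers for stronger inhibition), compound 3 gives 4480 nM, the higher of the two plain numbers, with compound 1 at 1710 nM. Compound 2 reaches only the assay limit > 10000 nM (the limit of > 10000 nM in this assay, at which 1 of the 3 values shown sits).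

Compound 4 `COc1cc2nccc(Oc3ccc(Nc4nn(C)cc4C(=O)NCC(C)C)cc3)c2cc1C(N)=O` is the next step from compound 3: isobutyl in place of 3-fluorophenyl on an amide-type nitrogen. Within the data shown here, two measured steps bear on a saturated chain on the amide nitrogen, an at least 5.8-fold higher number from compound 1 to compound 2 (0.76 log units; beyond the scatter) and an at least 2.2-fold lower number from compound 2 to compound 3 (0.34 log units; beyond the scatter); both put the cyclohexylmethyl compound weaker than either fluorophenyl compound. Another step toward weaker inhibition is therefore expected, likely again reaching the limit. Compound 4 is estimated at 15000 nM, between 5000 nM and 50000 nM, an expected step of a 3.3-fold higher number from compound 3 to compound 4 (0.52 log units; beyond the scatter).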

Compound 4, half-maximal inhibitory concentration: > 10000 nM
Compound 4: no number, only a limit; the forecaster's own chance of this, stated with the estimate: 65%; the middle value is on the limit's open side.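

Both saturated groups on the amide-type nitrogen now sit apart from the fluorophenyl compounds: in this assay, isobutyl gives an at least 2.2-fold higher number from compound 3 to compound 4 (0.34 log units; beyond the scatter) and an at least 5.8-fold higher number from compound 1 to compound 4 (0.76 log units; beyond the scatter), so the weak result is not confined to the larger cyclohexylmethyl of compound 2. The reading for compound 4 is a limit and not a number, as is that for compound 2: the limit of > 10000 nM in this assay, at which 2 of the 4 values shown sit. The step between these two compounds cannot be read, leaving isobutyl and cyclohexylmethyl unordered.

Going by these compounds, whether an unsubstituted phenyl or a benzyl on this nitrogen would hold a plain number stays open. So does the effect of a 4-fluorophenyl or of an amine-bearing chain.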